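The source may report more compounds than this note shows. Statements on the series, on what has been measured and on what is new or still open speak of the compounds shown alone.

Measured so far in a functional assay on B16-BL6 cells (Mus musculus) for cytotoxicity, read by MTT assay, with a stated time of 72 h; a lower number here means a stronger inhibitor, a higher number a weaker inhibitor:
compound 1 `COc1ccc(CCC(=O)c2ccc(O)cc2)c(OC)c1` gives 55500 nM
compound 2 `COc1ccc(CCC(=O)c2ccc(O)cc2)c(O)c1` gives 57800 nM

For the measured compounds named here, compound 2 and compound 1 lie within the scatter of each other; the single step between them, a 1.0-fold higher number from compound 1 to compound 2 (0.02 log units; within the scatter), was hydrogen in place of methyl on an oxygen on an aromatic ring. Compound 3 `O=C(CCc1ccc(O)cc1O)c1ccc(O)cc1` repeats that kind of change on compound 2: hydrogen in place of methyl on an oxygen on an aromatic ring. Going by the values given here, the one step that bears on it was flat, so no shift beyond the scatter is expected in this assay. Compound 3 is therefore estimated at 58000 nM (range 25000 nM to 130000 nM), an expected step of a 1.0-fold higher number from compound 2 to compound 3 (0.00 log units; within the scatter).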

Compound 3, half-maximal inhibitory concentration: > 100000 nM
Compound 3 was reported as a limit (the forecaster's own chance of this, stated with the estimate: 10%); at least 1.7-fold (0.23 log units) between middle value and limit.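

In this assay compound 3 gives > 100000 nM, which is a limit and not a number. Methoxy to hydroxy at the remaining methoxy gives an at least 1.7-fold higher number from compound 2 to compound 3 (0.23 log units; that floor lies within the scatter), so unlike the first such change, this step has only a floor and no measured size. The reading of this step rests on one value: the limit of > 100000 nM in this assay, at which 1 of the 3 values shown sits.

From the compounds shown here alone, whether compound 3 truly lies beyond the scatter of compound 2 stays open. Also open, going by these compounds, is how an amine or a carboxylic acid would read in place of the hydroxy, or a longer chain in place of the methyl on oxygen.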